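Trifluoromethyl in Place of Methyl on Compound 2

This account rests on a few compounds, and the source may have more. Where it says the series, first, only, none or still open, it means among the compounds named here.

Compound 2 `CC1(C(F)(F)F)C=C(/C(S)=N\CCC#N)c2cc([N+](=O)[O-])ccc2O1` reads 0.363 nM in a functional assay (aorta) with Rattus norvegicus as the target (on this read-out lower numbers stand for an effect already at smaller amounts and higher numbers for an effect only at larger amounts of compound), and compound 1 `C/N=C(/S)C1=CC(C(F)(F)F)(C(F)(F)F)Oc2ccc([N+](=O)[O-])cc21` reads 0.631 nM on the same read-out, two numbers within the usual scatter of each other. Compound 3 `N#CCC/N=C(/S)C1=CC(C(F)(F)F)(C(F)(F)F)Oc2ccc([N+](=O)[O-])cc21` differs from compound 2 by one change on a saturated ring carbon, trifluoromethyl in place of methyl (trifluoromethyl in place of methyl on a saturated ring carbon). Going by the values given here, no measured pair shows this change on its own. In this assay the expected step of a 1.2-fold higher number from compound 2 to compound 3 (0.09 log units; within the scatter) is small and stays within the scatter, with only a slight lean towards a higher number. Compound 3 is estimated at 0.45 nM in a range from 0.14 nM to 1.4 nM on this expectation.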

Compound 3, half-maximal effective concentration: 0.437 nM
Beside the measured number, compound 3's estimate is 1.0-fold (0.01 log units) above it, and the stated range covers the measured number.
By their numbers in this assay, from the lowest: compounds 2, 3 and 1 (each within the scatter of the next).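

In this assay, trifluoromethyl in place of methyl on the saturated ring carbon next to the ring oxygen gives a 1.2-fold higher number from compound 2 to compound 3 (0.08 log units; within the scatter) and so shows that this position accepts the change with no step beyond the scatter. Cyanomethyl in place of hydrogen on the saturated chain carbon bound to the double-bonded nitrogen gives a 1.4-fold lower number from compound 1 to compound 3 (0.16 log units; within the scatter) and likewise stays within the scatter. Nothing at hand gives a reason for either result. Still open, going by these compounds, is whether an ethyl group on that ring carbon, or an amine or a carboxylic acid at the end of that chain, would stay within the scatter of these numbers.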